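Replacing Fluoro with Pyrrolidin-1-yl: An Expected Read-out

The compounds below may be only part of what the source reports. "The series", "measured", "known", "first", "only" and "open" are said of these compounds alone.

compound 1 `O=C(/C=C/c1ccc(N2CCCC2)cc1)c1ccc(O)cc1` gives 60%
compound 2 `O=C(/C=C/c1ccc(F)cc1)c1ccc(O)cc1O` gives 56.7%

Both numbers come from an assay on isolated protein for inhibition of DNA topoisomerase 1 (Homo sapiens), tested at 20 uM; on this read-out higher numbers stand for a stronger effect at the one concentration tested and lower numbers for a weaker effect. Compound 2 has the lower of the two, but compound 1 sits within the usual scatter of it, so the two cannot be ranked. Compound 3 `O=C(/C=C/c1ccc(N2CCCC2)cc1)c1ccc(O)cc1O` has not yet been measured. It differs from compound 2 in a single place: pyrrolidin-1-yl in place of fluoro on an aromatic carbon. Among the compounds with values here, no pair of measured compounds isolates this change, so the data give no direction for it. The expected step is a number 3.3 percentage points higher from compound 2 to compound 3 (within the scatter), nothing beyond the scatter. For compound 3 the estimate in this assay is 60%, ranging from 45% to 75%.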

Compound 3, a percentage reported as inhibition, at one concentration (the size of the read-out at that concentration, not a potency): 64.4%
For compound 3 the middle estimate is 4.4 percentage points below the measured one; the range from low to high includes it.
By their numbers in this assay, from the lowest: compounds 2, 1 and 3 (each within the scatter of the next).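

Within the data shown here, this is the first pair that isolates the swap: pyrrolidin-1-yl in place of fluoro, on an aromatic carbon para to a large group, gives a number 7.7 percentage points higher from compound 2 to compound 3 (within the scatter) in this assay, so the two groups cannot be told apart here. Hydroxy in place of hydrogen on an aromatic carbon gives a number 4.4 percentage points higher from compound 1 to compound 3 (within the scatter), and this change cannot be told apart from the scatter either. No measurement shown offers an explanation for either step.

Going by these compounds, it remains open whether a methoxy group or a carboxylic acid at the position of the pyrrolidin-1-yl would move the read-out beyond the scatter.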